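This account rests on a few compounds, and the source may have more. Where it says the series, first, only, none or still open, it means among the compounds named here.

Measured in a functional assay on the whole organism (Tail, strain ICR) with Mus musculus as the target, in the tail flick test, with a stated time of 120 min, at a dose of 25 umol/kg by the oral route; on this read-out higher numbers stand for a stronger effect at the one dose given and lower numbers for a weaker effect:
compound 1, `O=C(CN(c1ncnc2c1ncn2C1CCCCO1)C1CC1)NCC(=O)OCc1ccccc1`, gives 17.2%;
compound 2, `NC(=O)C[C@H](NC(=O)CN(c1ncnc2c1ncn2C1CCCCO1)C1CC1)C(=O)OCc1ccccc1`, gives 29.2%;
compound 3, `CC(C)C[C@H](NC(=O)CN(c1ncnc2c1ncn2C1CCCCO1)C1CC1)C(=O)OCc1ccccc1`, gives 12.8%.

Compound 3 has the lowest of the three numbers, but one of its gaps is only a number 4.4 percentage points lower from compound 1 to compound 3 (within the scatter), while the other is a number 16.4 percentage points lower from compound 2 to compound 3 (beyond the scatter). Compound 4, `CSCC[C@H](NC(=O)CN(c1ncnc2c1ncn2C1CCCCO1)C1CC1)C(=O)OCc1ccccc1`, differs from compound 3 by (methylsulfanyl)methyl in place of isopropyl on a saturated chain carbon, two bonds along the chain from an amide-type nitrogen and a carbonyl carbon. Within the data shown here, the only step at this place is a number 16.4 percentage points lower from compound 2 to compound 3 (beyond the scatter), where a group carrying acceptors stood higher than isopropyl; the incoming group carries one acceptor, so a small rise is expected for compound 4, of about a number 6.2 percentage points higher from compound 3 to compound 4 (within the scatter), which stays near the scatter. Compound 4 is therefore estimated at 19%, within 9% to 31%.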

Compound 4, a percentage reported as activity, at one dose (the size of the read-out at that dose, not a potency): 28.7%
The estimate for compound 4 lay 9.7 percentage points below the measured number; measured number inside the range.
By their numbers in this assay, from the lowest: compounds 3 and 1 (each within the scatter of the next); then compounds 4 and 2 (each within the scatter of the next).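

With the count of heavy atoms unchanged, (methylsulfanyl)methyl in place of isopropyl gives a number 15.9 percentage points higher from compound 3 to compound 4 (beyond the scatter) in this assay, so this position responds to a swap within a chain of similar size. A side chain without a carbamoyl group can also match the carbamoylmethyl-bearing compound, with a number 0.5 percentage points lower from compound 2 to compound 4 (within the scatter), and the 2-(methylsulfanyl)ethyl chain gives a number 11.5 percentage points higher from compound 1 to compound 4 (beyond the scatter) against hydrogen. Nothing available explains these differences. Going by these compounds, it remains open whether the sulfur itself matters, and how a methoxyethyl chain, a longer thioether chain, a carboxylic acid or an amine would behave here.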